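The compounds below may be only part of what the source reports. "The series", "measured", "known", "first", "only" and "open" are said of these compounds alone.

Measured so far in an assay on isolated protein for displacement of a labelled ligand from metabotropic glutamate receptor 5 (Homo sapiens), with a stated time of 60 min, tested at 1 uM; on this read-out lower numbers stand for less inhibition and higher numbers for more inhibition at the one concentration tested (going by the name of the read-out):
- compound 1 `CC1CCN(c2c(S(=O)(=O)c3ccc(Cl)c(Cl)c3)cnc3cc(F)ccc23)CC1`: 94%
- compound 2 `CC1CCN(c2c(S(=O)(=O)c3ccc(F)c(F)c3)cnc3cc(Cl)ccc23)CC1`: 90%
- compound 3 `COc1cccc(S(=O)(=O)c2cnc3cc(Cl)ccc3c2N2CCC(C)CC2)c1`: 93%

Compound 3 stands second highest of the three numbers, but its gaps to compound 1 and to compound 2 both lie within the scatter, so the three are not separable. Among the measured compounds shown here, the one measured step that changes the group on the sulfonyl sulfur, a number 3 percentage points higher from compound 2 to compound 3 (within the scatter), also stayed within the scatter. Compound 4 `CC1CCN(c2c(S(=O)(=O)c3ccc(Cl)c(Cl)c3)cnc3cc(Cl)ccc23)CC1` differs from compound 3 by 3,4-dichlorophenyl in place of 3-methoxyphenyl on a sulfonyl sulfur, and compound 1 already carries this same 3,4-dichlorophenyl on a core that differs only in its halogen. Swapping groups on the sulfonyl sulfur has so far moved this assay by no more than the scatter, so the expected step for compound 4 is no change at the digits printed from compound 3 to compound 4 (within the scatter). Compound 4 is estimated at 93%, between 85% and 99%.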

Compound 4, a percentage reported as inhibition, at one concentration (the size of the read-out at that concentration, not a potency): 89%
The estimate for compound 4 lay 4 percentage points above the measured number, within the range that was stated.
By their numbers in this assay, from the lowest: compounds 4, 2, 3 and 1 (each within the scatter of the next).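

In this assay, 3,4-dichlorophenyl on the sulfonyl sulfur gives a number 4 percentage points lower from compound 3 to compound 4 (within the scatter) when it replaces 3-methoxyphenyl and a number 1 percentage points lower from compound 2 to compound 4 (within the scatter) when it replaces 3,4-difluorophenyl, so these swaps remain unresolved. The new information is a change on the shared core, chloro in place of fluoro on an aromatic carbon, which gives a number 5 percentage points lower from compound 1 to compound 4 (within the scatter) and so also cannot be told apart from repeat variation. Nothing available bears on these results.

Still open, on these data alone, is whether an amine or a carboxylic acid on the sulfonyl sulfur, in place of the aromatic ring, would separate from these compounds. Readings at one concentration also leave their potencies unknown.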